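This account rests on a few compounds, and the source may have more. Where it says the series, first, only, none or still open, it means among the compounds named here.

Measured so far in a functional assay on RAW264.7 cells (Mus musculus) for cytotoxicity, read by MTT assay, with a stated time of 48 h, tested at 25 uM; on this read-out lower numbers stand for a weaker effect and higher numbers for a stronger effect at the one concentration tested:

compound 1 `CS(=O)(=O)c1ccc(Cc2nnc3n2N=C(c2ccccc2)CS3)cc1` — 51%
compound 2 `CS(=O)(=O)c1ccc(Cc2nnc3n2N=C(c2ccc(-c4ccccc4)cc2)CS3)cc1` — 60.2%

On the numbers shown, compound 1 and compound 2 sit within the usual scatter of each other, the step of a number 9.2 percentage points higher from compound 1 to compound 2 (within the scatter) being within the scatter; compound 1 therefore cannot be placed apart from compound 2 on this read-out.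

Compound 3 `CS(=O)(=O)c1ccc(Cc2nnc3n2N=C(c2cc(Cl)sc2S(N)(=O)=O)CS3)cc1` is unmeasured. Relative to compound 1 the change is 5-chloro-2-sulfamoylthiophen-3-yl in place of phenyl on a carbon with a double bond to nitrogen. Among the measured compounds shown here, the only measured step, that from compound 1 to compound 2, adds phenyl onto an aromatic carbon and leaves the read-out unchanged beyond the scatter; it bears on the present change only loosely, since here the phenyl itself is exchanged rather than substituted. With no step of this kind in hand, the expectation for compound 3 is a step of about a number 1 percentage points lower from compound 1 to compound 3 (within the scatter), that is, none beyond the scatter. Compound 3 is thus estimated at 50%, with a range of 30% to 70% in this assay.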

Compound 3, a percentage reported as activity, at one concentration (the size of the read-out at that concentration, not a potency): 18.7%
Beside the measured number, compound 3's estimate is 31.3 percentage points above it; the whole stated range lies above it.
By their numbers in this assay, from the lowest: compound 3; then compounds 1 and 2 (each within the scatter of the next).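

In this assay, the exchange at the carbon with a double bond to nitrogen gives a number 32.3 percentage points lower from compound 1 to compound 3 (beyond the scatter), so the read-out responds strongly to the group at this place, which a number 9.2 percentage points higher from compound 1 to compound 2 (within the scatter) gave no sign of. The exchange replaces the phenyl itself, so this step covers a new ring and its two substituents together, and it cannot be divided among them. No measurement on hand gives a reason for the size of this step.

Still open, as far as these compounds go, is which part of 5-chloro-2-sulfamoylthiophen-3-yl carries the step: the thiophene ring, the chlorine or the sulfamoyl group. Also open, from the compounds shown here alone, is how other groups at this place would read, such as a phenyl bearing a carboxylic acid or an amine.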